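Hydrazide in Place of the Anilide Ring

The source may hold more compounds than are shown below. What is called first, only, known or untested is meant among the compounds shown, and "the series" means these compounds.

The three measured compounds share one core and differ only in the group on the amide-type nitrogen. In a physicochemical assay for solubility, in phosphate buffer, measured as kinetic solubility, with a stated time of 1 h, at pH 7.4 (a lower number here means a less soluble compound, a higher number a more soluble compound), compound 1 `COc1ccc2nc(C)cc(OCC(=O)Nc3ccccc3)c2c1` gives 63000 nM. Compound 2 `COc1ccc2nc(C)cc(OCC(=O)Nc3cc(C)ccc3C)c2c1` gives 45500 nM in this assay. Compound 3 `COc1ccc2nc(C)cc(OCC(=O)Nc3ccc(F)cc3)c2c1` gives 104000 nM in this assay and stands at the highest of the three numbers, although a 1.7-fold higher number from compound 1 to compound 3 (0.22 log units; within the scatter) and only a 2.3-fold higher number from compound 2 to compound 3 (0.36 log units; beyond the scatter). The remaining measured step, a 1.4-fold lower number from compound 1 to compound 2 (0.14 log units; within the scatter), rounds out the picture: changing substituents on the phenyl moves the number little.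

Compound 4 `COc1ccc2nc(C)cc(OCC(=O)NNC(=O)c3ccncc3)c2c1` goes well beyond such substituent swaps: ((pyridin-4-yl)carbonyl)amino in place of 4-fluorophenyl on an amide-type nitrogen. For the measured compounds named here, no measured step covers a change of this kind, so the three steps bear on compound 4 only by showing how closely the numbers of the phenyl-bearing compounds cluster. The entering group differs in kind, not merely in size, as the counted difference shows, and an upward shift in this assay larger than any measured step is expected. Compound 4 is therefore expected to give about 200000 nM, with a range from 80000 nM to 500000 nM. That estimate means a step of a 1.9-fold higher number from compound 3 to compound 4 (0.28 log units; within the scatter), expected to fall beyond the scatter.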

Compound 4, solubility: >= 375000 nM
Compound 4 was reported as a limit (the forecaster's own chance of this, stated with the estimate: 10%); middle value at least 1.8-fold (0.27 log units) away from the limit.
By their numbers in this assay, from the lowest: compounds 2, 1 and 3 (each within the scatter of the next, the first and the last beyond it). At a limit, above all of these: compound 4.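

In this assay, compound 4 is reported only as a limit of the assay and not as a number: the limit of >= 375000 nM in this assay, at which 1 of the 4 values shown sits. Set against this limit, ((pyridin-4-yl)carbonyl)amino on the amide-type nitrogen stands apart from each of the three aryl groups, with every step beyond the scatter (an at least 3.6-fold higher number from compound 3 to compound 4 (0.55 log units; beyond the scatter)) (an at least 5.9-fold higher number from compound 1 to compound 4 (0.77 log units; beyond the scatter)) (an at least 8.2-fold higher number from compound 2 to compound 4 (0.91 log units; beyond the scatter)). The earlier compounds shown here showed only how far the number moved among aryl groups at this position, and the largest step among them was modest (a 2.3-fold higher number from compound 2 to compound 3 (0.36 log units; beyond the scatter)), whereas this change shows that replacing the aryl group with one that carries a carbonyl and a further nitrogen can move the number further, even from compound 3, the highest of the three.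

As far as these compounds go, since the value of compound 4 is a limit, the full size of these steps stays open. From the compounds shown here alone, it also stays open which part of the entering group goes with the shift, the carbonyl and amino link or the pyridine ring, and a benzoyl group on the same amino link, or a simple acetyl group there, would separate the two.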